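The source may hold more compounds than are shown below. What is called first, only, known or untested is meant among the compounds shown, and "the series" means these compounds.

The series shares one core and differs only in its side groups. In a functional assay on HeLa cells (Homo sapiens) for cytotoxicity, read by MTT assay, with a stated time of 72 h (on this read-out lower numbers stand for stronger inhibition and higher numbers for weaker inhibition), compound 1 `Cc1cc(-c2ccccc2)n(/C(N)=N/S(=O)(=O)c2cc(C)c(Cl)cc2SCc2ccc(C(F)(F)F)cc2)n1` gives 19000 nM and compound 3 `Cc1cc(-c2ccccc2)n(/C(N)=N/S(=O)(=O)c2cc(C)c(Cl)cc2SCc2cccc(Cl)c2)n1` gives 8000 nM, while compound 2 `Cc1cc(S(=O)(=O)/N=C(\N)n2nccc2-c2ccccc2)c(SCc2ccc(C(F)(F)F)cc2)cc1Cl` gives 17000 nM, the second highest of the three numbers: compound 1 lies nearest, within the scatter, and compound 3 lies furthest, beyond it.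

Compound 4 `Cc1cc(S(=O)(=O)/N=C(\N)n2nccc2-c2ccccc2)c(SCc2ccccc2C(F)(F)F)cc1Cl` is built from compound 2 by one change, (2-(trifluoromethyl)phenyl in place of 4-(trifluoromethyl)phenyl on a saturated chain carbon bound to a sulfur).

Two measured steps offer a guide. The step of a 1.1-fold lower number from compound 1 to compound 2 (0.05 log units; within the scatter) shows that removing a methyl from the core barely moves the number. The step of a 2.4-fold lower number from compound 1 to compound 3 (0.38 log units; beyond the scatter) shows that swapping the aryl group on the saturated chain carbon bound to a sulfur can shift the number modestly. Within the data shown here, the change to compound 4 sits at that same place, but moves the trifluoromethyl around the ring rather than exchanging it, and no measured compound carries a 2-(trifluoromethyl)phenyl there. A step of at most modest size is therefore expected, a 1.4-fold lower number from compound 2 to compound 4 (0.15 log units; within the scatter), with a lower number slightly more likely than a higher one.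

For compound 4 in this assay the estimate is 12000 nM, expected to fall between 5000 nM and 30000 nM.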

Compound 4, half-maximal inhibitory concentration: 20000 nM
Compound 4: the middle estimate sits 1.7-fold (0.22 log units) below what was measured; the measured number falls inside the stated range.
By their numbers in this assay, from the lowest: compound 3; then compounds 2, 1 and 4 (each within the scatter of the next).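

In this assay the exchange of 4-(trifluoromethyl)phenyl for 2-(trifluoromethyl)phenyl on a saturated chain carbon bound to a sulfur gives a 1.2-fold higher number from compound 2 to compound 4 (0.07 log units; within the scatter) and so, with the same atoms joined differently, the two compounds cannot be told apart in this test. Among these compounds, the only earlier step at this place is a 2.4-fold lower number from compound 1 to compound 3 (0.38 log units; beyond the scatter) and it brought in a different group, 3-chlorophenyl, on the core that keeps its methyl; the new pair therefore adds that not every exchange at this place moves the number beyond the scatter, and it gives a first reading there on the core without that methyl. Nothing measured here explains this result.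

The compounds shown leave open whether the 3-chlorophenyl exchange would give a similar step on the core without the methyl. They also leave open whether an amine or a carboxylic acid on this aryl ring, or a longer chain in place of the saturated chain carbon bound to a sulfur, would move the number further than any step seen so far.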